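The source may hold more compounds than are shown below. What is called first, only, known or untested is meant among the compounds shown, and "the series" means these compounds.

Measured so far in a functional assay on UO-31 cells (Homo sapiens) for inhibition, read by sulforhodamine B assay, with a stated time of 48 h; a higher number here means that more compound is tolerated, a lower number that less compound is tolerated:

- compound 1, `O=C(Nc1cccc(-n2cc(-c3ccncc3)c(-c3ccc(Cl)c(O)c3)n2)c1)Nc1ccc(Cl)c(Cl)c1`: > 32500 nM
- compound 2, `COc1cc(-c2nn(-c3cccc(NC(=O)Nc4ccc(Cl)c(C(F)(F)F)c4)c3)cc2-c2ccncc2)ccc1Cl`: > 32500 nM

Compound 1 reaches only the limit of this assay, > 32500 nM, so no number is known for it. Compound 2 likewise sits at the limit of this assay, > 32500 nM, and no number is known for it either. Both recorded values in this assay are limits, as the tally confirms: the limit of > 32500 nM in this assay, at which 2 of the 2 values shown sit. Within the measured pair there is no step in one place, so nothing is known about how any single change moves the read-out.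

Compound 3, `O=C(Nc1cccc(-n2cc(-c3ccncc3)c(-c3ccc(Cl)c(O)c3)n2)c1)Nc1ccc(Cl)c(C(F)(F)F)c1`, is not yet measured. It differs from compound 2 by hydrogen in place of methyl on an oxygen on an aromatic ring. Compound 1 carries the same hydroxy group and gave only a limit. With both measured values at the limit, the step from compound 2 to compound 3 is expected to be a step that the limit leaves unreadable from compound 2 to compound 3, none beyond the scatter, and compound 3 is expected to give 40000 nM in this assay, most likely again as a limit, between 20000 nM and 100000 nM.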

Compound 3, concentration lethal to 50% of the cells: > 32500 nM
Compound 3: only a limit was reported; the forecaster's own chance of this, stated with the estimate: 85%; the middle value is on the limit's open side.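

In this assay compound 3 gives > 32500 nM, which is a limit. No step from compound 2 to compound 3 or from compound 1 to compound 3 can be read: the limit of > 32500 nM in this assay, at which 3 of the 3 values shown sit.

Still open is whether methoxy to hydroxy or chloro to trifluoromethyl changes the read-out at all, since no compound shown has a numeric value.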